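Styrylsulfonamide series: cytotoxicity on K562 cells

The compounds below may be only part of what the source reports. "The series", "measured", "known", "first", "only" and "open" are said of these compounds alone.

Measured compounds:
compound 1 `COc1ccc(/C=C/S(=O)(=O)Nc2c(F)c(F)c(F)c(F)c2F)cc1N` 35000 nM
compound 2 `COc1ccc(NS(=O)(=O)/C=C/c2c(OC)cc(OCCCC(=O)O)cc2OC)cc1[N+](=O)[O-]` 100000 nM
compound 3 `COC(=O)CNc1cc(NS(=O)(=O)/C=C/c2c(OC)cc(OC)cc2OC)ccc1OC` 350 nM

All three were run in a functional assay on K562 cells (Homo sapiens) for cytotoxicity, read by trypan blue exclusion, with a stated time of 96 h; on this read-out lower numbers stand for stronger inhibition and higher numbers for weaker inhibition. Compound 3 stands lowest of the three numbers, and its steps to the other two are beyond the scatter, so it is the most potent compound of the set: compound 1 gives 35000 nM and compound 2 gives 100000 nM, the latter carrying a free acid on its chain and standing weakest.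

Compound 4 `COc1cc(OC)c(/C=C/S(=O)(=O)Nc2ccc(OC)c(NC(C(=O)O)c3ccc(Cl)cc3)c2)c(OC)c1` differs from compound 3 in one place: carboxy(4-chlorophenyl)methyl in place of (methoxycarbonyl)methyl on a nitrogen on an aromatic ring. A free acid enters where a methyl ester stood, and the group grows by a chlorinated aromatic ring. Going by the values given here, no measured pair shows this change, so its effect is not known from the set; compound 2 only shows that the one other acid-bearing compound gave a weak number, in a different position and context.

The step is expected to be a moderate loss, read as a 4.3-fold higher number from compound 3 to compound 4 (0.63 log units; beyond the scatter). Compound 4 is estimated at 1500 nM, within 300 nM to 8000 nM.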

Compound 4, half-maximal inhibitory concentration: 15 nM
Compound 4: the middle estimate sits 100-fold (2.00 log units) above what was measured, outside the stated range (below it).
By their numbers in this assay, from the lowest: compound 4; then compound 3; then compound 1; then compound 2.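

In this assay, going by these compounds alone, carboxy(4-chlorophenyl)methyl in place of (methoxycarbonyl)methyl on a nitrogen on an aromatic ring gives a 23-fold lower number from compound 3 to compound 4 (1.37 log units; beyond the scatter) and is the only single-place change read so far. This position therefore accepts a carboxylic acid together with a larger group carrying an aromatic ring, and the methyl ester of compound 3 is not required for a low number. Nothing measured here explains why the step runs this way.

The carboxylic acid and the 4-chlorophenyl ring enter together, so the step cannot yet be divided between them. The methyl ester of compound 4 and the analogue with a plain phenyl ring in place of 4-chlorophenyl would separate the two contributions.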